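Pyridin-2-yl in place of pyridin-4-yl on the carbonyl

A few compounds are considered here, and "the series" means these few. Any claim that something is new, unique, unknown or untested is made for them only; others in the source may bear on it.

In a physicochemical assay for lipophilicity, read by HPLC, measured as chromatographic lipophilicity, at pH 7.4 (on this read-out higher numbers stand for higher lipophilicity and lower numbers for lower lipophilicity), compound 1 `O=C(C1CCCCC1)N1N=CCC1c1ccccc1` reads 5.9 and compound 2 `O=C(c1ccccc1)N1N=CCC1c1ccccc1` reads 4.6 while compound 3 `O=C(c1ccncc1)N1N=CCC1c1ccccc1` reads 2.7 as the lowest of the three numbers. Compound 4 `O=C(c1ccccn1)N1N=CCC1c1ccccc1` is not yet measured and differs from compound 3 by pyridin-2-yl in place of pyridin-4-yl on a carbonyl carbon with the same atoms joined differently. The closest measured steps are both large (a number 1.90 log units lower from compound 2 to compound 3 (beyond the scatter) and a number 3.20 log units lower from compound 1 to compound 3 (beyond the scatter)) but each exchanges a different group for pyridin-4-yl. Going by the values given here, no measured step only rejoins the same atoms. A smaller, upward move is expected, and the estimated step is a number 0.50 log units higher from compound 3 to compound 4 (beyond the scatter). Its direction remains uncertain. Compound 4 is estimated at 3.2 (expected range 2.6 to 3.9).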

Compound 4, distribution coefficient: 2.4
Estimate against measurement, compound 4: 0.80 log units above; the measured number lies below the stated range.
By their numbers in this assay, from the lowest: compounds 4 and 3 (each within the scatter of the next); then compound 2; then compound 1.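

At this carbonyl carbon in this assay, pyridin-2-yl in place of pyridin-4-yl gives a number 0.30 log units lower from compound 3 to compound 4 (within the scatter), so the two pyridinyl groups are not told apart here. The large steps recur with the new group: pyridin-2-yl in place of phenyl gives a number 2.20 log units lower from compound 2 to compound 4 (beyond the scatter), and in place of cyclohexyl it gives a number 3.50 log units lower from compound 1 to compound 4 (beyond the scatter). No measurement at hand explains this result.

Still open, going by these compounds, is where pyridin-3-yl or a ring bearing an amine would read at this carbon. Also open, on these data alone, is whether the match between the pyridinyl groups holds on another core.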